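Removing the Chloro Group from a Weak Cytotoxic Phenol

The source may hold more compounds than are shown below. What is called first, only, known or untested is meant among the compounds shown, and "the series" means these compounds.

In a functional assay on Bel-7402 cells (Homo sapiens) for cytotoxicity, read by sulforhodamine B assay (on this read-out lower numbers stand for stronger inhibition and higher numbers for weaker inhibition), compound 2 `COCc1cc(O)cc(Cl)c1O` gives 58100 nM, the highest of the two numbers recorded so far. Going by the values given here, the only other measured compound, compound 1 `OCc1cc(O)c(Cc2cc(O)ccc2O)c(Cl)c1O`, gives 6000 nM in this assay, a clearly lower number that lies beyond the scatter. Compound 3 `COCc1cc(O)ccc1O` differs from compound 2 by one change: hydrogen in place of chloro on an aromatic carbon. Among the compounds with values here, no measured pair shows this change, so the step is expected to be small, most likely a modest loss that is within or just beyond the scatter, as in a 1.4-fold higher number from compound 2 to compound 3 (0.14 log units; within the scatter). Compound 3 is therefore estimated at 80000 nM, with a range from 25000 nM to 250000 nM.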

Compound 3, half-maximal inhibitory concentration: > 100000 nM
Compound 3 ended at the assay's limit; the forecaster's own chance of this, stated with the estimate: 15%; middle value at least 1.2-fold (0.09 log units) away from the limit.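

In this assay, the result for compound 3 is a limit and not a number, so this change can be sized only by a floor: the limit of > 100000 nM in this assay, at which 1 of the 3 values shown sits. Hydrogen in place of chloro, on the aromatic carbon ortho to a hydroxy group, gives an at least 1.7-fold higher number from compound 2 to compound 3 (0.23 log units; that floor lies within the scatter). Going by these compounds, this shows no gain from losing the chloro group, while the true size of the loss remains unknown.

On these data alone, whether a bromo group, a methyl group or an amine at this carbon would lower the number remains open, as does the effect of the same change on compound 1.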